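A second chloro group on a well-tolerated compound

The source may hold more compounds than are shown below. What is called first, only, known or untested is meant among the compounds shown, and "the series" means these compounds.

Compound 1 `Clc1cccc(/N=N/N2CCCC2)c1` gives >= 100000 nM as its result
Compound 2 `Clc1ccc(/N=N/N2CCCC2)cc1` gives > 100000 nM as its result
Compound 3 `Clc1ccc(/N=N/N2CCCC2)cc1Cl` has not yet been measured

In an ADME assay on Vero cells (Chlorocebus sabaeus) for cytotoxicity, read by crystal violet staining (a higher number here means that more compound is tolerated, a lower number that less compound is tolerated), compound 2 gives > 100000 nM as its result, which is a limit of the assay and not a number. Compound 1 gives >= 100000 nM as its result, and this too is a limit. Compound 3 has chloro in place of hydrogen on an aromatic carbon, ortho to a chloro group (chloro in place of hydrogen on an aromatic carbon). Among the compounds with values here, no measured step shows what such a change does. Starting from the limit of compound 2 (> 100000 nM), a small shift towards less compound tolerated in this assay is expected, or none beyond the scatter. The expected step of an at least 1.1-fold lower number from compound 2 to compound 3 (0.07 log units; that floor lies within the scatter) is only an estimate. For compound 3 the estimated value is 85000 nM with an expected range of 35000 nM to 100000 nM, and the assay may again report only a limit.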

Compound 3, half-maximal cytotoxic concentration: 58000 nM
Compound 3: the middle estimate sits 1.5-fold (0.17 log units) above what was measured, and the stated range covers the measured number.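

In this assay, within the data shown here, compound 3 gives 58000 nM, the only value in this set that is a number and not a limit of the assay. Chloro in place of hydrogen on an aromatic carbon, ortho to a chloro group, gives an at least 1.7-fold lower number from compound 2 to compound 3 (0.23 log units; that floor lies within the scatter) and also an at least 1.7-fold lower number from compound 1 to compound 3 (0.23 log units; that floor lies within the scatter) so a second chloro group on the ring is tolerated, with no step shown beyond the scatter. Both steps are floors and not measured sizes, because compound 2 and compound 1 each stand at a limit: the limit of > 100000 nM in this assay, at which 1 of the 3 values shown sits, and (the limit of >= 100000 nM in this assay, at which 1 of the 3 values shown sits).

On these data alone, it remains open whether a methyl group or an amine on this same carbon would give a similar value. The compounds shown also leave open what a second chloro group would do at another place on the ring.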